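A few compounds are considered here, and "the series" means these few. Any claim that something is new, unique, unknown or untested is made for them only; others in the source may bear on it.

Compound 1 `COC(=O)N(Cc1ccccc1F)c1c(N)nc(-c2nn(Cc3ccccc3F)c3ncccc23)nc1N`: 53.3 mL/min/kg
Compound 2 `COC(=O)N(Cc1cccc(F)c1)c1c(N)nc(-c2nn(Cc3ccccc3F)c3ncccc23)nc1N`: 53.3 mL/min/kg
Compound 3 `Nc1nc(-c2nn(Cc3ccccc3F)c3ncccc23)nc(N)c1NC(=O)OC1CCC1`: 23.3 mL/min/kg

In an ADME assay on cells (Hepatocyte, Rattus norvegicus) for pharmacokinetics, read by LC-MS, with a stated time of 90 min, tested at 1 uM (on this read-out lower numbers stand for slow clearance and higher numbers for fast clearance), compound 3 has the lowest number of the three, and its gap to each of the other two lies beyond the usual scatter. Compound 4 `Nc1nc(-c2nn(Cc3ccccc3F)c3ncccc23)nc(N)c1N1CCOC1=O` has not yet been measured. It differs from compound 3 in one place, on an aromatic carbon, where 2-oxo-1,3-oxazolidin-3-yl stands in place of (cyclobutyloxycarbonyl)amino (2-oxo-1,3-oxazolidin-3-yl in place of (cyclobutyloxycarbonyl)amino on an aromatic carbon).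

The only measured step among these compounds is no change at the digits printed from compound 1 to compound 2 (within the scatter). It moves a fluorine elsewhere in the molecule, so it offers no direct guide to this change. The indirect evidence is thin. Compound 4 lacks the amide hydrogen of compound 3, and so does compound 2, which stands at 53.3 mL/min/kg. Compound 2 also differs from compound 4 in other ways, so this supports only a slight lean towards faster clearance, not a firm trend. The expected change is therefore small and within the scatter, and the estimated step is a 1.4-fold higher number from compound 3 to compound 4 (0.14 log units; within the scatter). For compound 4 the estimated clearance is 32 mL/min/kg, with an expected range of 15 mL/min/kg to 60 mL/min/kg.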

Compound 4, clearance: 6.67 mL/min/kg
For compound 4 the middle estimate is 4.8-fold (0.68 log units) above the measured one; the whole stated range lies above it.
By their numbers in this assay, from the lowest: compound 4; then compound 3; then compounds 1 and 2 (each within the scatter of the next).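

In this assay, among these compounds, putting the closed ring 2-oxo-1,3-oxazolidin-3-yl in place of the open (cyclobutyloxycarbonyl)amino on this aromatic carbon gives a 3.5-fold lower number from compound 3 to compound 4 (0.54 log units; beyond the scatter) and so shows that the read-out responds to the group held at this position, something the only earlier step, a moved fluorine on a different part of the molecule, could not show. This single swap changes several things at once: the group that enters has fewer heavy atoms, has no hydrogen-bond donor, and has a five-membered ring with hetero atoms instead of a four-membered ring of carbon only, so the step cannot separate these differences. Nothing measured here explains the lower number.

Going by these compounds, it remains open whether the ring as such or the missing amide hydrogen goes with the lower number, a question that a pyrrolidin-2-one, with carbon in place of the ring oxygen, or a six-membered cyclic carbamate at the same position would help to address. Also open, on these data alone, is whether the same swap would give a similar step on a core carrying a different group in place of the fluorobenzyl substituent.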